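The compounds below may be only part of what the source reports. "The series", "measured", "known", "first", "only" and "open" are said of these compounds alone.

Compound 1 `CCCCNc1nc(N)nc(C)c1CCCCc1ccccc1` gives 857 nM in an assay on HEK293 cells for agonist activity at Toll-like receptor 8 (Homo sapiens), read by spectrophotometry; on this read-out lower numbers stand for an effect already at smaller amounts and higher numbers for an effect only at larger amounts of compound.
Compound 2 `CCCCNc1nc(N)nc(C)c1CCCC` gives 780 nM in this assay.
Compound 3 `CCCCNc1nc(N)nc(C)c1CCCn1cccn1` gives 1050 nM in this assay.

Compound 3 gives the highest of the three numbers, yet the steps of a 1.2-fold higher number from compound 1 to compound 3 (0.09 log units; within the scatter) and a 1.3-fold higher number from compound 2 to compound 3 (0.13 log units; within the scatter) both stay within the scatter, so the three measured compounds are indistinguishable on this read-out.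

Compound 4 `CCCCNc1nc(N)nc(C)c1CCCN1CCCC1` differs from compound 3 by pyrrolidin-1-yl in place of 1H-pyrazol-1-yl on a saturated chain carbon, three bonds along the chain from an aromatic carbon. Among the measured compounds shown here, two measured steps touch this same chain position: the step of a 1.2-fold higher number from compound 1 to compound 3 (0.09 log units; within the scatter) and the step of a 1.3-fold higher number from compound 2 to compound 3 (0.13 log units; within the scatter). Neither moved the number beyond the scatter, and the step of a 1.1-fold lower number from compound 1 to compound 2 (0.04 log units; within the scatter) at a neighbouring chain position also stayed within it. Nothing in these data shows a group at this position shifting this assay beyond the scatter, so the step of a 1.1-fold lower number from compound 3 to compound 4 (0.02 log units; within the scatter) is expected to stay within it as well. Compound 4 is therefore estimated at 1000 nM, with a range from 400 nM to 2500 nM.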

Compound 4, half-maximal effective concentration: 110 nM
For compound 4 the middle estimate is 9.1-fold (0.96 log units) above the measured one; the whole stated range lies above it.
By their numbers in this assay, from the lowest: compound 4; then compounds 2, 1 and 3 (each within the scatter of the next).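

Among the compounds shown here, this chain position had looked indifferent to its substituent, but it does respond in this assay: pyrrolidin-1-yl in place of 1H-pyrazol-1-yl gives a 9.5-fold lower number from compound 3 to compound 4 (0.98 log units; beyond the scatter), the first step beyond the scatter. The same group also separates compound 4 from the other two compounds, with a 7.1-fold lower number from compound 2 to compound 4 (0.85 log units; beyond the scatter) and a 7.8-fold lower number from compound 1 to compound 4 (0.89 log units; beyond the scatter), while those earlier compounds remain within the scatter of one another. Both rings have 5 heavy atoms, so the change is from a five-membered aromatic ring with 2 hetero atoms to a five-membered non-aromatic ring with 1 hetero atom, and no measurement available here accounts for the shift. As far as these compounds go, it remains open whether the shift belongs to the pyrrolidine ring itself or extends to other amines at this place, such as piperidine or an open-chain dimethylamino group. Also open, from the compounds shown here alone, is how it would respond to a longer chain carrying the pyrrolidin-1-yl group.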